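The compounds below may be only part of what the source reports. "The series", "measured", "known", "first", "only" and "open" are said of these compounds alone.

Working notes on a small chloro series. Compound 1 `O=C1/C(=C/c2cccc(Cl)c2)Cc2ccccc21` and compound 2 `O=C1/C(=C/c2ccc(Cl)cc2)Cc2ccccc21` share one core and both carry a chloro group, placed differently on the aromatic ring. In a functional assay on P388 cells (Mus musculus) for inhibition (on this read-out higher numbers stand for weaker inhibition and lower numbers for stronger inhibition), compound 1 gives 26300 nM, a weak reading. For compound 2, this assay returns only a limit, > 50000 nM, so this compound has no exact number to serve as a starting point.

The next compound is compound 3 `Cc1ccc(/C=C2\Cc3ccccc3C2=O)cc1`, which keeps the core of compound 2 and changes one group: methyl in place of chloro on an aromatic carbon. This is methyl in place of chloro on an aromatic carbon, para to a large group.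

Within the data shown here, no measured step shows the size of this exchange, and the two measured compounds offer no direct precedent for methyl. The working expectation in this assay is therefore no step beyond the scatter and no favoured direction, and another reading reported only as a limit is quite possible. The expected step is an at least 1.1-fold lower number from compound 2 to compound 3 (0.04 log units; that floor lies within the scatter). The estimated value for compound 3 is 45000 nM, with an expected range from 18000 nM to 110000 nM.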

Compound 3, half-maximal inhibitory concentration: 38600 nM
Beside the measured number, compound 3's estimate is 1.2-fold (0.07 log units) above it, within the range that was stated.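

In this assay, methyl in place of chloro on an aromatic carbon, para to a large group, gives compound 3 an exact reading at a position where compound 2 yields only a limit. The exchange comes to an at least 1.2-fold lower number from compound 2 to compound 3 (0.11 log units; that floor lies within the scatter), so the series now has a floor for this step but no upper size for it. The step can be stated only as a floor because compound 2 has no exact number to anchor it: the limit of > 50000 nM in this assay, at which 1 of the 3 values shown sits.

From the compounds shown here alone, the true size of the change from chloro to methyl remains open, including whether it exceeds the usual scatter, as does the effect of methyl at the place the chloro occupies in compound 1. Also open is how an amine, a carboxylic acid or a longer chain on this aromatic carbon would read in this assay, so the compounds shown give no trend for this position.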